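Swapping the Halogenated Benzyl Group in a Benzimidazole Acylurea

The compounds below may be only part of what the source reports. "The series", "measured", "known", "first", "only" and "open" are said of these compounds alone.

Compound 2 `Cc1ccc(NC(=O)NC(=O)c2ccc(OCc3ccccc3Cl)cc2)cc1-c1nc2ccccc2[nH]1` was measured in a functional assay on MNK45 cells (Homo sapiens) for inhibition, read by MTT assay, with a stated time of 48 h (on this read-out lower numbers stand for stronger inhibition and higher numbers for weaker inhibition), and gave 21500 nM. Among the compounds with values here, the only other compound measured alongside it is compound 1 `Cc1ccc(NC(=O)NC(=O)c2ccc(OCc3ccccc3)cc2)cc1-c1nc2ccccc2[nH]1`, which in this assay gives 35100 nM; the two values lie within the usual scatter of each other, so neither can be called stronger or weaker than the other on this evidence. Within the data shown here, the step between them, a 1.6-fold lower number from compound 1 to compound 2 (0.21 log units; within the scatter), is the single measured step available and describes a chloro in place of hydrogen on an aromatic carbon.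

Compound 3 `Cc1ccc(NC(=O)NC(=O)c2ccc(OCc3ccc(F)cc3)cc2)cc1-c1nc2ccccc2[nH]1` has not yet been measured in this assay. It differs from compound 2 in one place: 4-fluorophenyl in place of 2-chlorophenyl on a saturated chain carbon bound to an oxygen on an aromatic ring. Among the measured compounds shown here, the only measured step bears on it indirectly, since it shows that adding the chlorine to the benzyl ring of compound 1 moved the number less than the scatter. Removing that chlorine and placing a fluorine elsewhere on the same ring is therefore expected to change the number little, with an expected step of a 1.3-fold higher number from compound 2 to compound 3 (0.11 log units; within the scatter). Compound 3 is thus estimated at 28000 nM, with a range from 10000 nM to 80000 nM.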

Compound 3, half-maximal inhibitory concentration: 240 nM
For compound 3 the middle estimate is 120-fold (2.07 log units) above the measured one; measured number outside the range, below it.
By their numbers in this assay, from the lowest: compound 3; then compounds 2 and 1 (each within the scatter of the next).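

In this assay, the benzyl ring proves to be a place where one substituent can carry a large effect: 4-fluorophenyl in place of 2-chlorophenyl gives a 90-fold lower number from compound 2 to compound 3 (1.95 log units; beyond the scatter), and fluoro in place of hydrogen on the same ring gives a 150-fold lower number from compound 1 to compound 3 (2.17 log units; beyond the scatter). The earlier pair had shown only a step within the scatter, which could have suggested that this ring tolerates substitution without much change, but compound 3 now stands well apart from both compound 1 and compound 2, so the outcome depends on which substituent is present and where it sits. Nothing shown here accounts for the size of this difference.

Compound 2 and compound 3 differ both in the halogen and in where it sits on the ring, so the compounds shown cannot separate these two changes. Within the data shown here, they also leave open whether a group other than a halogen on this ring, such as a methoxy group or a nitrile, would reach a number like the one compound 3 gives, 240 nM.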